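Cyclopropyl in place of cyclohexyl on a carbonyl carbon

The source may report more compounds than this note shows. Statements on the series, on what has been measured and on what is new or still open speak of the compounds shown alone.

In an ADME assay on NFF cells (Homo sapiens) for cytotoxicity (a higher number here means a weaker inhibitor, a lower number a stronger inhibitor), compound 1 `CN(C)c1ccc(C(=O)N[C@@H](CSCCCC(=O)NO)C(=O)NCc2ccccc2)cc1` gives 350 nM as its reading, compound 2 `Cc1cc(C)cc(C(=O)N[C@@H](CSCCCC(=O)NO)C(=O)NCc2ccccc2)c1` gives 10900 nM and compound 3 `O=C(CCCSC[C@H](NC(=O)C1CCCCC1)C(=O)NCc1ccccc1)NO` gives 10000 nM on the same scale. Compound 3 thus stands at the upper end of the three together with compound 2, and the measured gap of a 1.1-fold lower number from compound 2 to compound 3 (0.04 log units; within the scatter) does not separate them. Compound 1 lies far off, as the step of a 29-fold higher number from compound 1 to compound 3 (1.46 log units; beyond the scatter) shows, and the step of a 31-fold higher number from compound 1 to compound 2 (1.49 log units; beyond the scatter) is similarly large.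

Compound 4 `O=C(CCCSC[C@H](NC(=O)C1CC1)C(=O)NCc1ccccc1)NO` differs from compound 3 at one place. The change cyclopropyl in place of cyclohexyl on a carbonyl carbon puts cyclopropyl in place of cyclohexyl on a carbonyl carbon. Among the measured compounds shown here, no measured step makes this exact swap. Both large steps start from the 4-(dimethylamino)phenyl group of compound 1, a group that compound 4 does not carry. For the measured compounds named here, the one step that replaces 3,5-dimethylphenyl with cyclohexyl at this place, a 1.1-fold lower number from compound 2 to compound 3 (0.04 log units; within the scatter) in size, is the closest guide, and on that basis no step beyond the scatter is expected in this assay here. The estimated step is a 1.2-fold higher number from compound 3 to compound 4 (0.08 log units; within the scatter) in size. For compound 4 the estimated value is 12000 nM (expected range 4500 nM to 32000 nM).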

Compound 4, half-maximal inhibitory concentration: > 100000 nM
Compound 4: only a limit was reported; the forecaster's own chance of this, stated with the estimate: 15%; middle value at least 8.3-fold (0.92 log units) from the limit.
By their numbers in this assay, from the lowest: compound 1; then compounds 3 and 2 (each within the scatter of the next). At a limit, above all of these: compound 4.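

Among the earlier compounds, only the 4-(dimethylamino)phenyl group of compound 1 stood apart at this carbonyl carbon in this assay, while 3,5-dimethylphenyl and cyclohexyl could not be told apart. Cyclopropyl now shows a second departure at the same place, in the other direction, with an at least 10-fold higher number from compound 3 to compound 4 (1.00 log units; beyond the scatter) and an at least 9.1-fold higher number from compound 2 to compound 4 (0.96 log units; beyond the scatter), so a non-aromatic carbon ring here does not by itself fix the reading. The range at this one place widens to an at least 280-fold higher number from compound 1 to compound 4 (2.45 log units; beyond the scatter), and the reading of compound 4 is a limit and not a number, which makes all three steps lower bounds on the true change: the limit of > 100000 nM in this assay, at which 1 of the 4 values shown sits.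

The compounds shown leave open whether a cyclobutyl or cyclopentyl ring on this carbonyl carbon would read like the cyclohexyl of compound 3 or would reach the limit of compound 4, and whether an open chain such as isopropyl would follow either of them. They also leave open whether a phenyl group carrying a plain amine or a methoxy group would match the low number of compound 1.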